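The compounds below may be only part of what the source reports. "The series", "measured", "known", "first", "only" and "open" are said of these compounds alone.

Among the compounds with values here, compound 2 `O=C1O[C@@H](Cn2ccnn2)CN1c1ccc(-n2cc(-c3ccccn3)cn2)c(F)c1` is one of two compounds measured in an ADME assay on L02 cells (Homo sapiens) for cytotoxicity, read by MTT assay, with a stated time of 48 h; on this read-out lower numbers stand for stronger inhibition and higher numbers for weaker inhibition; in that assay compound 2 gives 49 ug/mL. Compound 1 `CN1CCN(C[C@H]2CN(c3ccc(-n4cc(-c5ccccn5)cn4)c(F)c3)C(=O)O2)CC1` carries 4-methylpiperazin-1-yl where compound 2 carries 1H-1,2,3-triazol-1-yl; in this assay compound 1 gives 70 ug/mL. Compound 2 therefore shows the lowest number of the two, but the step of a 1.4-fold lower number from compound 1 to compound 2 (0.15 log units; within the scatter) leaves compound 1 and compound 2 indistinguishable on this read-out.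

Compound 3 `CNC(=O)[C@H]1CN(c2ccc(-n3cc(-c4ccccn4)cn3)c(F)c2)C(=O)O1` has not yet been measured. It differs from compound 2 by methylcarbamoyl in place of (1H-1,2,3-triazol-1-yl)methyl on a saturated ring carbon. Within the data shown here, no measured step changes this position of the shared core in the same way; the one measured step, a 1.4-fold lower number from compound 1 to compound 2 (0.15 log units; within the scatter), swaps groups at a different place and stays within the scatter. Among the measured compounds shown here, with only that step to go by, no change beyond the scatter is expected for compound 3 in this assay, so the step of a 1.2-fold higher number from compound 2 to compound 3 (0.09 log units; within the scatter) is the estimate. Compound 3 is accordingly expected to give about 60 ug/mL in this assay, within a range of 30 ug/mL to 120 ug/mL.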

Compound 3, half-maximal inhibitory concentration: 217 ug/mL
Compound 3: the middle estimate sits 3.6-fold (0.56 log units) below what was measured; the measured number lies above the stated range.
By their numbers in this assay, from the lowest: compounds 2 and 1 (each within the scatter of the next); then compound 3.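

Within the data shown here, the change at this position is the first in this assay to move the number beyond the scatter: methylcarbamoyl in place of (1H-1,2,3-triazol-1-yl)methyl gives a 4.4-fold higher number from compound 2 to compound 3 (0.65 log units; beyond the scatter), and methylcarbamoyl in place of (4-methylpiperazin-1-yl)methyl gives a 3.1-fold higher number from compound 1 to compound 3 (0.49 log units; beyond the scatter). Compound 1 and compound 2 stayed within the scatter of each other with two different rings on the saturated chain carbon, so the earlier pair showed no sensitivity to the group, whereas the group without a ring, carrying a hydrogen-bond donor, reads as weaker inhibition than either. Nothing available explains this rise.

The compounds shown leave open which part of the change goes with the higher number, since the ring leaves and the hydrogen-bond donor and the double bond outside aromatic rings enter in a single step. A carboxylic acid or a primary amine on this saturated ring carbon, or a longer chain ending in methylcarbamoyl, would help separate these parts.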